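Shortening the chain on an aromatic nitrogen

A few compounds are considered here, and "the series" means these few. Any claim that something is new, unique, unknown or untested is made for them only; others in the source may bear on it.

Compound 1 `c1nc2cc3c(cc2[nH]1)C1CNCC3C1` gives 0.15 nM in an assay on HEK293 cells for binding affinity to Neuronal acetylcholine receptor; alpha4/beta2 (Homo sapiens); on this read-out higher numbers stand for weaker inhibition and lower numbers for stronger inhibition.
Compound 2 `c1ccc(-c2cccc3c2C2CNCC3C2)cc1` gives 1600 nM in this assay.
Compound 3 `CCCn1c(C)nc2cc3c(cc21)C1CNCC3C1` gives 0.19 nM in this assay.

Compound 3 stands second highest among the three measured numbers. Its nearest neighbour is compound 1, whose number is lower by an amount that lies within the scatter, so the two cannot be told apart. Its furthest neighbour is compound 2, whose number is far higher, well beyond the scatter.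

Compound 4 `Cc1nc2cc3c(cc2n1C)C1CNCC3C1` is not yet measured. It differs from compound 3 by hydrogen in place of ethyl on a saturated chain carbon bound to an aromatic nitrogen. Within the data shown here, the data hold no measured step for this kind of change. Compound 1, which carries no chain at all on that nitrogen, sits within the scatter of compound 3, so the length of this chain appears to matter little here. Compound 4 is therefore expected to give a number close to compound 3, with the step of a 1.1-fold higher number from compound 3 to compound 4 (0.02 log units; within the scatter) expected to lie within the scatter. The estimate for compound 4 in this assay is 0.2 nM, with a range from 0.07 nM to 0.6 nM.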

Compound 4, inhibition constant: 0.31 nM
Compound 4: middle estimate off by 1.6-fold (0.19 log units), on the low side; measured number inside the range.
By their numbers in this assay, from the lowest: compounds 1, 3 and 4 (each within the scatter of the next, the first and the last beyond it); then compound 2.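

Going from propyl to methyl on the aromatic nitrogen, with hydrogen in place of ethyl on a saturated chain carbon bound to that nitrogen, gives the only step of its kind among these compounds (a 1.6-fold higher number from compound 3 to compound 4 (0.21 log units; within the scatter)) in this assay. For this pair, the ethyl portion of the chain can be removed without a difference that can be told from the scatter, so the result adds a direct single-place comparison at this position. No measured evidence bears on why this change leaves the two compounds so close.

On these data alone, whether a longer chain such as hexyl, or a chain ending in an amine or a carboxylic acid, would also stay close to compound 3 remains open. The two chains compared here show only that this one shortening can be tolerated, not how far the position would accept other groups.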